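From ethyl to cyclopropyl on an amide-type nitrogen

The source may hold more compounds than are shown below. What is called first, only, known or untested is meant among the compounds shown, and "the series" means these compounds.

Measured in an in vitro ADME assay on microsomes (Homo sapiens) for metabolic stability; a higher number here means that the compound lasts longer, a lower number that the compound disappears faster:
- compound 1 `O=C(Nc1ccccc1)Nc1ccc(-c2nc(N3CC4CCC(C3)O4)c3cnn(C4CCC5(CC4)OCCO5)c3n2)cc1`: 0.217 h
- compound 2 `O=C(Nc1ccncc1)Nc1ccc(-c2nc(N3CC4CCC(C3)O4)c3cnn(C4CCC5(CC4)OCCO5)c3n2)cc1`: 0.217 h
- compound 3 `CCNC(=O)Nc1ccc(-c2nc(N3CC4CCC(C3)O4)c3cnn(C4CCC5(CC4)OCCO5)c3n2)cc1`: 0.167 h

Compound 3 stands level with the other two, within the scatter. Compound 4 `O=C(Nc1ccc(-c2nc(N3CC4CCC(C3)O4)c3cnn(C4CCC5(CC4)OCCO5)c3n2)cc1)NC1CC1` carries cyclopropyl in place of ethyl on an amide-type nitrogen. Within the data shown here, no measured step covers this exact exchange. The nearest steps changed the group at that same place: ethyl for phenyl gave a 1.3-fold lower number from compound 1 to compound 3 (0.11 log units; within the scatter), ethyl for pyridin-4-yl gave a 1.3-fold lower number from compound 2 to compound 3 (0.11 log units; within the scatter), and pyridin-4-yl for phenyl gave no change at the digits printed from compound 1 to compound 2 (within the scatter). With all three inside the scatter, no step beyond it is expected in this assay. The expected change is a 1.1-fold higher number from compound 3 to compound 4 (0.06 log units; within the scatter). For compound 4 the estimated half-life is 0.19 h, with an expected range from 0.11 h to 0.33 h.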

Compound 4, half-life: 0.15 h
For compound 4 the middle estimate is 1.3-fold (0.10 log units) above the measured one; the range from low to high includes it.
By their numbers in this assay, from the lowest: compounds 4, 3, 1 and 2 (each within the scatter of the next).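

In this assay the cyclopropyl group on the amide-type nitrogen gives a 1.1-fold lower number from compound 3 to compound 4 (0.05 log units; within the scatter) and a 1.4-fold lower number from compound 2 to compound 4 (0.16 log units; within the scatter) and also a 1.4-fold lower number from compound 1 to compound 4 (0.16 log units; within the scatter) at this place. A three-membered ring of carbon thus joins ethyl, phenyl and pyridin-4-yl, and all four stand level within the scatter. Nothing available explains this result. On these data alone, whether an amine, a carboxylic acid or a longer chain at this place would shift the half-life beyond the scatter remains open. So does whether a change elsewhere on the shared core would do so.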